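A few compounds are considered here, and "the series" means these few. Any claim that something is new, unique, unknown or untested is made for them only; others in the source may bear on it.

Measured so far:
compound 1, `Nc1cc(N)c2nc(-c3ccccc3)c(NCc3ccc(Cl)c(Cl)c3)nc2c1`, 4170 nM
compound 2, `Nc1cc(N)c2nc(-c3ccccc3)c(Oc3ccc(F)cc3)nc2c1`, 13500 nM
compound 3, `CCOC(=O)[C@H](CCC(=O)O)NC(=O)c1ccc(Oc2nc3cc(N)cc(N)c3nc2-c2ccccc2)cc1`, 11200 nM

All three were tested in a functional assay on UO-31 cells (Homo sapiens) for inhibition, read by sulforhodamine B assay, with a stated time of 48 h; a higher number here means a weaker inhibitor of growth, a lower number a stronger inhibitor of growth. Compound 2 gives the highest number of the three; compound 3 lies within the scatter of it, while compound 1 sits beyond the scatter, at a lower number. Within the data shown here, no pair here differs in a single place, so no step between measured compounds can be drawn.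

Compound 4, `Nc1cc(N)c2nc(-c3ccccc3)c(NCc3ccc(F)cc3)nc2c1`, has not yet been tested in this assay. It differs from compound 2 in one place:
(4-fluorobenzyl)amino in place of 4-fluorophenoxy on an aromatic carbon
Compound 1 carries a benzylamino group on the shared core and gives 4170 nM, so a lower number than compound 2 is expected for compound 4. The expected step from compound 2 to compound 4 in this assay is a 2.7-fold lower number from compound 2 to compound 4 (0.43 log units; beyond the scatter), beyond the scatter. Compound 4 is estimated at 5000 nM, between 2000 nM and 14000 nM.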

Compound 4, concentration for 50% growth inhibition: 3800 nM
Estimate against measurement, compound 4: 1.3-fold (0.12 log units) above, and the stated range covers the measured number.
By their numbers in this assay, from the lowest: compounds 4 and 1 (each within the scatter of the next); then compounds 3 and 2 (each within the scatter of the next).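

Among these compounds, the step in this assay from 4-fluorophenoxy to (4-fluorobenzyl)amino on this aromatic carbon is a 3.6-fold lower number from compound 2 to compound 4 (0.55 log units; beyond the scatter) and gives the first direct reading of this change at this position. The ring on the benzylamino group can also change here without a readable effect, since 4-fluorophenyl in place of 3,4-dichlorophenyl gives a 1.1-fold lower number from compound 1 to compound 4 (0.04 log units; within the scatter) and rests on this one pair. Nothing shown accounts for either step.

As far as these compounds go, whether a phenethylamino group or a carboxylic acid on the benzyl ring would hold this level remains open.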